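Taking the Methoxy Off Compound 1

A few compounds are considered here, and "the series" means these few. Any claim that something is new, unique, unknown or untested is made for them only; others in the source may bear on it.

Measured so far in an in vitro ADME assay on microsomes from liver (Homo sapiens) for metabolic stability; on this read-out higher numbers stand for fast clearance and lower numbers for slow clearance:
compound 1, `COc1ccc(C2CCc3nc[nH]c3C2)cc1`: 16 mL.min-1.g-1
compound 2, `COCc1ccccc1C1Cc2nccn2C1`: < 7 mL.min-1.g-1

Among the compounds with values here, compound 1 `COc1ccc(C2CCc3nc[nH]c3C2)cc1` gives 16 mL.min-1.g-1 in this assay, and this is the only outright number among the values in hand. Compound 2 `COCc1ccccc1C1Cc2nccn2C1` gives < 7 mL.min-1.g-1 in this assay, which is a limit of the assay rather than a number, as noted in the limit of < 7 mL.min-1.g-1 in this assay, at which 1 of the 2 values shown sits. Within the data shown here, no two measured compounds differ in only one place, so no measured step is available to lean on.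

Compound 3 `c1ccc(C2CCc3nc[nH]c3C2)cc1` has not yet been measured. It differs from compound 1 by hydrogen in place of methoxy on an aromatic carbon.

Among the measured compounds shown here, with no measured step to guide it, the expectation rests on compound 1 alone: compound 3 is expected to come out somewhat lower than compound 1 in this assay, though the change could also stay within the usual scatter. The expected step is a 1.6-fold lower number from compound 1 to compound 3 (0.20 log units; within the scatter). Compound 3 is therefore estimated at 10 mL.min-1.g-1, with a likely range from 4 mL.min-1.g-1 to 28 mL.min-1.g-1.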

Compound 3, intrinsic clearance in microsomes in the Homo sapiens assay: 7 mL.min-1.g-1
Estimate against measurement, compound 3: 1.4-fold (0.15 log units) above; the measured number falls inside the stated range.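

Within the data shown here, this is the first measured step: in the Homo sapiens assay compound 1 gives 16 mL.min-1.g-1 and compound 3 gives 7 mL.min-1.g-1, which shows that the methoxy on the aromatic carbon can give way to hydrogen with clearance moving down rather than up, and the swap gives a 2.3-fold lower number from compound 1 to compound 3 (0.36 log units; beyond the scatter). In a physicochemical assay for lipophilicity, at pH 7.4 (a higher number here means a more lipophilic compound, a lower number a more polar compound), compound 1 gives 2.6 and compound 3 gives 2.6: the same swap gives no change at the digits printed from compound 1 to compound 3 (within the scatter), so the pair parts in one read-out and not in the other. Compound 2 stands at a limit of the assay and not at a number: the limit of < 7 mL.min-1.g-1 in the Homo sapiens assay, at which 1 of the 3 values shown sits.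

Only hydrogen and methoxy appear at this position, and a fluorine atom, a nitrile or an amine there remains an open question in both read-outs. Going by these compounds, whether the same swap would give a similar step on a different core is also open, as this single pair is the only one that speaks to it.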